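Replacing a branched amino chain with an aminocyclohexyl ring

The source may hold more compounds than are shown below. What is called first, only, known or untested is meant among the compounds shown, and "the series" means these compounds.

Compound 1 `CC(C)(C)C[C@H](N)C(=O)Nc1cc2cc[nH]c(=O)c2cc1Cl`: 845 nM
Compound 2 `CC(C)[C@H](N)C(=O)Nc1cc2cc[nH]c(=O)c2cc1Cl`: 12 nM
Compound 3 `O=C(Nc1cc2cc[nH]c(=O)c2cc1Cl)[C@@H]1CCCN1`: 35 nM

In an assay on isolated protein for inhibition of Rho-associated protein kinase 2 (Homo sapiens) (a lower number here means a stronger inhibitor, a higher number a weaker inhibitor), compound 1 stands highest of the three numbers, so it is the weakest inhibitor here: compound 3 lies a 24-fold lower number from compound 1 to compound 3 (1.38 log units; beyond the scatter) away, and compound 2 further still at a 70-fold lower number from compound 1 to compound 2 (1.85 log units; beyond the scatter). Compound 4 `N[C@H]1CC[C@@H](C(=O)Nc2cc3cc[nH]c(=O)c3cc2Cl)CC1` has not yet been measured. It differs from compound 1 in one place: 4-aminocyclohexyl in place of 1-amino-3,3-dimethylbutyl on a carbonyl carbon.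

Among the measured compounds shown here, two measured steps bear on this change, since both also exchange the 1-amino-3,3-dimethylbutyl group for something smaller or ring-shaped on the same carbonyl carbon. The step of a 70-fold lower number from compound 1 to compound 2 (1.85 log units; beyond the scatter) and the step of a 24-fold lower number from compound 1 to compound 3 (1.38 log units; beyond the scatter) were both large and both lowered the number well beyond the scatter. The change to 4-aminocyclohexyl keeps the amine and the carbonyl link while trading the open chain for a six-membered ring, much as compound 3 did. A large drop is therefore expected, of about a 28-fold lower number from compound 1 to compound 4 (1.45 log units; beyond the scatter). For compound 4 the estimate in this assay is 30 nM, with a likely range from 8 nM to 120 nM.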

Compound 4, half-maximal inhibitory concentration: 15 nM
Estimate against measurement, compound 4: 2.0-fold (0.30 log units) above; the range from low to high includes it.
By their numbers in this assay, from the lowest: compounds 2 and 4 (each within the scatter of the next); then compound 3; then compound 1.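

In this assay, 4-aminocyclohexyl and 1-amino-3,3-dimethylbutyl hold the same number of heavy atoms, yet the number falls sharply (a 56-fold lower number from compound 1 to compound 4 (1.75 log units; beyond the scatter)), so atom count alone does not set the result at this place on the carbonyl carbon. The ring also stands level with the open 1-amino-2-methylpropyl group (a 1.3-fold higher number from compound 2 to compound 4 (0.10 log units; within the scatter)) and gives a stronger inhibitor than the smaller pyrrolidin-2-yl ring (a 2.3-fold lower number from compound 3 to compound 4 (0.37 log units; beyond the scatter)), showing that this position accepts more than one shape of amine-bearing group. No evidence on the cause of these differences is available. Still open, going by these compounds, is how the other stereoisomer of 4-aminocyclohexyl would compare. Also open, on these data alone, is whether a piperidin-4-yl ring, or a hydroxyl in place of the amine on the cyclohexyl ring, would keep the number this low.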